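A few compounds are considered here, and "the series" means these few. Any claim that something is new, unique, unknown or untested is made for them only; others in the source may bear on it.

The measured compounds:
Compound 1, `COc1nc2ccc(Br)cc2cc1C(c1ccccc1)n1cc(-c2ccccc2F)nn1`, gives 14.7% in an ADME assay on PANC-1 cells (Homo sapiens) for cytotoxicity, read by sulforhodamine B assay, with a stated time of 48 h, tested at 10 uM; a higher number here means more inhibition at the concentration tested (going by the name of the read-out), a lower number less inhibition.
Compound 2, `COc1nc2ccc(Br)cc2cc1C(c1ccccc1)n1cc(CCO)nn1`, gives 19.8% in this assay.
Compound 3, `COc1nc2ccc(Br)cc2cc1C(c1ccccc1)n1cc(CCCCCO)nn1`, gives 19.6% in this assay.

Compound 3 holds the second highest of these three numbers, all of which sit close together: the nearest number lies a number 0.2 percentage points lower from compound 2 to compound 3 (within the scatter) and the furthest a number 4.9 percentage points higher from compound 1 to compound 3 (within the scatter), both within the scatter. The step to compound 4, `COc1nc2ccc(Br)cc2cc1C(c1ccccc1)n1cc(C2CC2)nn1`, is cyclopropyl in place of 5-hydroxypentyl on an aromatic carbon. All three measured steps also swap the group on this aromatic carbon of the shared core and bear on the change here: a number 5.1 percentage points higher from compound 1 to compound 2 (within the scatter), a number 4.9 percentage points higher from compound 1 to compound 3 (within the scatter) and a number 0.2 percentage points lower from compound 2 to compound 3 (within the scatter), each within the scatter. Whether an aryl group, a short hydroxyalkyl chain or a longer one sits there, the number in this assay has hardly moved, so no step beyond the scatter is expected from a number 2.6 percentage points lower from compound 3 to compound 4 (within the scatter). Compound 4 is therefore estimated at 17% in this assay, with a range from 7% to 28%.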

Compound 4, a percentage reported as inhibition, at one concentration (the size of the read-out at that concentration, not a potency): 21.8%
Compound 4: the middle estimate sits 4.8 percentage points below what was measured; the range from low to high includes it.
By their numbers in this assay, from the lowest: compounds 1, 3, 2 and 4 (each within the scatter of the next).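

Compound 4 puts a small non-aromatic ring on this aromatic carbon of the shared core, yet in this assay the change gives a number 2.2 percentage points higher from compound 3 to compound 4 (within the scatter) and a number 2 percentage points higher from compound 2 to compound 4 (within the scatter) and also a number 7.1 percentage points higher from compound 1 to compound 4 (within the scatter) as its steps from the earlier groups. The cyclopropyl group has 0 hydrogen-bond donors and 0 hydrogen-bond acceptors, so the hydroxy group of the two chains is not required to keep the number within the scatter of theirs. An aryl group, two hydroxyalkyl chains and now a three-membered ring all read alike at this position, and none of the four compounds stands apart.

As far as these compounds go, whether an amine, a carboxylic acid or a larger ring such as cyclohexyl on this carbon would move the number beyond the scatter stays open. Nothing shown gives a measured reason for how little these numbers differ.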